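Capping the Phenol: Methoxy Analogue of an Inactive Pair

The compounds below may be only part of what the source reports. "The series", "measured", "known", "first", "only" and "open" are said of these compounds alone.

Measured compounds:
Compound 1, `O=C(Nc1cccc(-n2cc(-c3ccncc3)c(-c3cc(O)cc(Cl)c3)n2)c1)Nc1ccc(Cl)c(C(F)(F)F)c1`: 101%
Compound 2, `O=C(Nc1cccc(-n2cc(-c3ccncc3)c(-c3cc(O)cc(Cl)c3)n2)c1)Nc1ccc(Cl)c(Cl)c1`: 102%

In a functional assay on SW-620 cells (Homo sapiens) for inhibition, read by sulforhodamine B assay, with a stated time of 48 h, tested at 1 uM (a higher number here means a weaker effect of the compound at the concentration tested, a lower number a stronger effect), compound 1 gives 101%, a reading that indicates essentially no growth inhibition at the tested concentration. Compound 2 gives 102% in this assay, and the shift a number 1 percentage points higher from compound 1 to compound 2 (within the scatter) is too small to separate the two; both sit at the level of untreated cells.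

Compound 3, `COc1cc(Cl)cc(-c2nn(-c3cccc(NC(=O)Nc4ccc(Cl)c(C(F)(F)F)c4)c3)cc2-c2ccncc2)c1`, carries the change methyl in place of hydrogen on an oxygen on an aromatic ring relative to compound 1. Within the data shown here, the only measured step, from compound 1 to compound 2, alters a different part of the molecule and shows no movement beyond the scatter, so it offers no direct guide to capping the hydroxy group. With nothing in the shown data pointing toward a gain or loss, the expectation for compound 3 is a step of a number 1 percentage points lower from compound 1 to compound 3 (within the scatter), that is, none beyond the scatter. The estimated value for compound 3 is 100%, with a range from 88% to 110%.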

Compound 3, a percentage reported as activity, at one concentration (the size of the read-out at that concentration, not a potency): 63%
Compound 3: the middle estimate sits 37 percentage points above what was measured; measured number below the stated range.
By their numbers in this assay, from the lowest: compound 3; then compounds 1 and 2 (each within the scatter of the next).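

Capping the oxygen, hydroxy to methoxy, gives a number 38 percentage points lower from compound 1 to compound 3 (beyond the scatter) in this assay, so a 3-chloro-5-methoxyphenyl group brings a growth-inhibiting effect at the tested concentration that neither earlier compound showed. This position therefore responds strongly to one added methyl, whereas the other site changed so far gave a number 1 percentage points higher from compound 1 to compound 2 (within the scatter) when chloro stood in place of trifluoromethyl. The data at hand offer no measurement that accounts for this difference.

From the compounds shown here alone, it remains open whether the effect is specific to methyl on this oxygen, or whether a longer chain such as ethyl or propyl would keep, deepen or lose it, and whether an amine in place of the oxygen would behave like the hydroxy or the methoxy. Also open, going by these compounds, is whether the same hydroxy to methoxy change would act alike on compound 2, which carries chloro instead of trifluoromethyl.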